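A few compounds are considered here, and "the series" means these few. Any claim that something is new, unique, unknown or untested is made for them only; others in the source may bear on it.

Compound 1 `CCCCOc1ccc2c(Cl)ccnc2c1` and compound 2 `CCCCCCCCOc1ccc2c(Cl)ccnc2c1` share one core, while compound 3 `CCOc1ccc2c(NCCN(C)C)ccnc2c1` and compound 4 `CCCCCCOc1ccc2c(NCCN(C)C)ccnc2c1` share another; the difference between the two cores is not broken down here. In a functional assay on DLD-1 cells (Homo sapiens) for cytotoxicity, read by MTT assay, with a stated time of 48 h (a lower number here means a stronger inhibitor, a higher number a weaker inhibitor), compound 1 gives 3780 nM, and compound 2 gives 4500 nM, so that the change butyl in place of hydrogen on a saturated chain carbon, four bonds along the chain from an oxygen on an aromatic ring made a step of a 1.2-fold higher number from compound 1 to compound 2 (0.08 log units; within the scatter). Compound 3 gives 6240 nM in this assay. The change from compound 3 to compound 4 is butyl in place of hydrogen on a saturated chain carbon, two bonds along the chain from an oxygen on an aromatic ring, the same kind of change as before, though here it sits two bonds along the chain from the ring oxygen rather than four. Because the earlier step was a 1.2-fold higher number from compound 1 to compound 2 (0.08 log units; within the scatter), the expected step is a 1.1-fold higher number from compound 3 to compound 4 (0.05 log units; within the scatter), with compound 4 estimated at 7000 nM in this assay, between 3000 nM and 16000 nM.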

Compound 4, half-maximal inhibitory concentration: 1870 nM
For compound 4 the middle estimate is 3.7-fold (0.57 log units) above the measured one, outside the stated range (below it).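

On the core of compound 3, butyl in place of hydrogen gave a 3.3-fold lower number from compound 3 to compound 4 (0.52 log units; beyond the scatter) in this assay. Set beside the earlier step, the same change did not carry over from one core to the other: the same change on two cores in this assay, a 1.2-fold higher number (0.08 log units; within the scatter) from compound 1 to compound 2 and a 3.3-fold lower number (0.52 log units; beyond the scatter) from compound 3 to compound 4, 4.0-fold (0.60 log units) apart, beyond the scatter of two such steps. This rests on a single pair for each core, and the change sits four bonds along the chain from the ring oxygen in one pair and two bonds along in the other, so it does not show whether the core or the place of the change accounts for the gap.

The compounds shown leave open what a longer chain, such as decyloxy in place of the hexyloxy of compound 4, would do on this core. They also leave open whether either step would hold for other pairs on the two cores.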